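Phenyl for Isopentyl on the Aromatic Nitrogen of Compound 1

The source may report more compounds than this note shows. Statements on the series, on what has been measured and on what is new or still open speak of the compounds shown alone.

For the measured compounds named here, compound 1 `CC(C)CCn1c(N2CCN(C)CC2)nc2ccccc21` stands highest of the three numbers measured so far in a functional assay on ileum for inhibition of histamine H1 receptor (Cavia porcellus) (on this read-out higher numbers stand for weaker inhibition and lower numbers for stronger inhibition), where compound 1 gives 1400 nM. In this assay compound 2 `CCOCCn1c(N2CCNCC2)nc2ccccc21` gives 11 nM and compound 3 `CCCCN1CCN(c2nc3ccccc3n2CCOCC)CC1` gives 15 nM. Going by the values given here, the one step between compounds that differ in a single place is a 1.4-fold higher number from compound 2 to compound 3 (0.13 log units; within the scatter), butyl in place of hydrogen on an amine nitrogen in a ring. Compound 1 differs from compound 3 in two places at once, both on the substituent of the aromatic nitrogen and on the piperazine nitrogen, and its gap to compound 3 and to compound 2 is beyond the scatter.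

Compound 4 `CN1CCN(c2nc3ccccc3n2-c2ccccc2)CC1` arises from compound 1 by phenyl in place of isopentyl on an aromatic nitrogen. No measured step changes only the group on this aromatic nitrogen, so nothing shown bears directly on the change. On these data alone, the gap from compound 1 to compounds 2 and 3 suggests that this position can move the number a great deal, in either direction, but the scale for phenyl is unknown. Compound 4 is therefore expected to give 400 nM, with a range from 60 nM to 2500 nM, which would mean an expected step of a 3.5-fold lower number from compound 1 to compound 4 (0.54 log units; beyond the scatter).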

Compound 4, half-maximal inhibitory concentration: 760 nM
Compound 4: middle estimate off by 1.9-fold (0.28 log units), on the low side; low and high end bracket the measured number.
By their numbers in this assay, from the lowest: compounds 2 and 3 (each within the scatter of the next); then compounds 4 and 1 (each within the scatter of the next).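

In this assay, for the compounds shown here, a 1.8-fold lower number from compound 1 to compound 4 (0.27 log units; within the scatter) is the first step that changes only the group on the aromatic nitrogen, with the 4-methylpiperazin-1-yl group held in place. With that group fixed, replacing isopentyl, an open chain with no ring, by phenyl, a six-membered aromatic ring of carbon only, leaves the two numbers within the scatter of each other, so this pair shows that the position can accept either group without a distinguishable shift in this read-out. Nothing available bears on the reason for this result.

The compounds shown do not separate the contribution of the group on the aromatic nitrogen from that of the group on the piperazine nitrogen in the wider gap around compound 1, and no single-place step links the ethoxyethyl chain of compound 2 to either isopentyl or phenyl. On these data alone, it also remains open what a benzyl group, a pyridine ring or a chain ending in an amine would give on this aromatic nitrogen.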